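The compounds below may be only part of what the source reports. "The series", "measured", "known", "first", "only" and "open" are said of these compounds alone.

Measured compounds:
compound 1, `COc1cc(-c2cc(/C=C/C(=O)c3ccc(Cl)c(Cl)c3)[nH]n2)cc(OC)c1OC`, gives 54%
compound 2, `COc1ccc(-c2cc(/C=C/C(=O)c3cc(OC)c(OC)c(OC)c3)[nH]n2)cc1OC`, gives 89%

Of the compounds shown here, two sharing one core have been tested in a functional assay on COLO 205 cells (Homo sapiens) for cytotoxicity, read by sulforhodamine B assay, with a stated time of 48 h, tested at 1 uM; on this read-out higher numbers stand for a weaker effect at the one concentration tested and lower numbers for a stronger effect. Compound 1 stands lowest of the two numbers, and so shows the stronger effect at the single concentration used; its nearest neighbour is compound 2, which lies higher by an amount beyond the usual scatter. Among the compounds with values here, the two differ in more than one place, so no single step between them can be read off, and only their two values speak for themselves.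

Compound 3, `COc1ccc(C(=O)/C=C/c2cc(-c3cc(OC)c(OC)c(OC)c3)n[nH]2)cc1OC`, has not yet been measured in this assay. It differs from compound 1 in one place: 3,4-dimethoxyphenyl in place of 3,4-dichlorophenyl on a carbonyl carbon. The part of the molecule on the carbonyl carbon in compound 3 is thus of the methoxy-bearing kind, as it is in compound 2.

For compound 3 a move towards a weaker effect is expected, a step from compound 1 of a number 24 percentage points higher from compound 1 to compound 3 (beyond the scatter), because compound 2 gives 89%. The estimate for compound 3 in this assay is 78%, within a range from 58% to 98%.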

Compound 3, a percentage reported as activity, at one concentration (the size of the read-out at that concentration, not a potency): 95%
Estimate against measurement, compound 3: 17 percentage points below, and the stated range covers the measured number.
By their numbers in this assay, from the lowest: compound 1; then compounds 2 and 3 (each within the scatter of the next).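

Replacing 3,4-dichlorophenyl with 3,4-dimethoxyphenyl on a carbonyl carbon is a single change, and in this assay it gives a number 41 percentage points higher from compound 1 to compound 3 (beyond the scatter) on the way towards a weaker effect at the one concentration tested. The two earlier compounds differed in more than one place, so they could not tie their gap to any one part of the molecule; this pair shows that the group at this position can, on its own, set much of the effect seen in this assay, with the dichlorinated ring the one of the two that goes with the stronger effect. Why the two groups behave so differently is not something the data can say, as no measurement bearing on the cause is at hand.

The compounds shown leave open how the read-out would respond on this carbonyl carbon to a ring with a single chlorine, a trifluoromethyl group, an amine or a carboxylic acid, so the step marks only two points at this position. They also leave open whether the same replacement gives a step of similar size when the rest of the core carries other groups.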